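The source may hold more compounds than are shown below. What is called first, only, known or untested is meant among the compounds shown, and "the series" means these compounds.

Working notes on the series. Compound 2 `CC(C(=O)NCc1ccc(Cl)cc1)c1ccc(NS(C)(=O)=O)c(F)c1` gives 1060 nM in an assay on CHO cells for displacement of a labelled ligand from transient receptor potential cation channel subfamily V member 1 (Rattus norvegicus); a higher number here means a weaker inhibitor, a lower number a stronger inhibitor. Compound 1 `COc1cc(C2(C(=O)NCc3ccc(C(C)(C)C)cc3)CC2)ccc1NS(C)(=O)=O` gives 750 nM in this assay, a number within the scatter of that of compound 2, so no order between the two is claimed. Compound 3 `Cc1ccc(CNC(=O)C(C)c2ccc(NS(C)(=O)=O)c(F)c2)cc1` gives 3100 nM in this assay, the number furthest from compound 2 and the only one clearly apart from it. Among the compounds with values here, the single measured step that bears on the present question is a 2.9-fold higher number from compound 2 to compound 3 (0.47 log units; beyond the scatter), a modest rise from exchanging the chloro for a carbon group at that aromatic carbon.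

Compound 4 `CC(C(=O)NCc1ccc(C2CC2)cc1)c1ccc(NS(C)(=O)=O)c(F)c1` carries the change (cyclopropyl in place of chloro on an aromatic carbon). Within the data shown here, no measured compound holds a cyclopropyl at this position, so the expectation rests on the methyl precedent alone: a carbon substituent there gave a higher number, and a cyclopropyl is taken as likely to do the same, though the size of the effect is uncertain. The step from compound 2 to compound 4 is therefore expected to read a 1.7-fold higher number from compound 2 to compound 4 (0.23 log units; within the scatter). Compound 4 is estimated at 1800 nM in this assay, with a range from 800 nM to 4000 nM.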

Compound 4, inhibition constant: 411 nM
Beside the measured number, compound 4's estimate is 4.4-fold (0.64 log units) above it, outside the stated range (below it).
By their numbers in this assay, from the lowest: compounds 4, 1 and 2 (each within the scatter of the next, the first and the last beyond it); then compound 3.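

At this position a carbon group does not in itself raise the number: a 2.6-fold lower number from compound 2 to compound 4 (0.41 log units; beyond the scatter) in this assay runs opposite to a 2.9-fold higher number from compound 2 to compound 3 (0.47 log units; beyond the scatter) for the methyl. The comparison between the two carbon groups, a 7.5-fold lower number from compound 3 to compound 4 (0.88 log units; beyond the scatter) in this assay, shows that the outcome depends on which carbon group stands on the aromatic carbon, and that cyclopropyl, unlike methyl, gives a lower number than chloro. Nothing at hand accounts for this reversal.

On these data alone, whether the lower number belongs to the three-membered ring or extends to an isopropyl, a cyclobutyl or a longer chain on this core stays open. Compound 1, with its tert-butyl, differs from compound 4 in more than one place and does not settle the matter.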